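The compounds below may be only part of what the source reports. "The series", "measured", "known", "first", "only" and "open" are said of these compounds alone.

Measured in an ADME assay on a cell-free system (plasma, Rattus norvegicus) for metabolic stability, read by LC-MS, with a stated time of 60 min, tested at 100 uM; a higher number here means that more of the compound is left, a lower number that less of the compound is left:

- Compound 1 `Cc1c(OCCCCOc2ccc(F)c(C(=O)O)c2)ccc(C(=O)CC(C)(C)C)c1O`: 83%
- Compound 2 `Cc1c(OCCCCOc2cccc(C(=O)O)c2)ccc(C(=O)CC(C)C)c1O`: 100%
- Compound 3 `Cc1cc(OCCCCOc2ccc(C(=O)CC(C)C)c(O)c2C)ccc1C(=O)O`: 101%

Compound 3 stands level with compound 2 at the top of this small set, the two lying within the scatter of each other, while compound 1 lies lower, beyond the scatter. The next compound, compound 4 `Cc1c(OCCCCOc2ccc(F)c(C(=O)O)c2)ccc(C(=O)CC(C)C)c1O`, differs from compound 3 in one group: 3-carboxy-4-fluorophenyl in place of 4-carboxy-3-methylphenyl on an oxygen on a saturated carbon. Among the measured compounds shown here, only one measured step touches that place, a number 1 percentage points higher from compound 2 to compound 3 (within the scatter), and it stays within the scatter. Compound 1, at 83%, already carries 3-carboxy-4-fluorophenyl, but it also has a different chain on its carbonyl, and the data do not separate these two differences. A small downward step is therefore expected, most likely within the scatter. The expected change is a number 7 percentage points lower from compound 3 to compound 4 (within the scatter). For compound 4 the estimated value is 94%, with an expected range of 81% to 105%.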

Compound 4, percent of the compound remaining: 101%
For compound 4 the middle estimate is 7 percentage points below the measured one; low and high end bracket the measured number.
By their numbers in this assay, from the lowest: compound 1; then compounds 2, 3 and 4 (each within the scatter of the next).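

In this assay, 3-carboxy-4-fluorophenyl on this oxygen stands level with 4-carboxy-3-methylphenyl (no change at the digits printed from compound 3 to compound 4 (within the scatter)), and fluoro in place of hydrogen on an aromatic carbon also leaves the number level (a number 1 percentage points higher from compound 2 to compound 4 (within the scatter)). Among the compounds shown here, the only step beyond the scatter lies at the other place, with hydrogen in place of methyl on a saturated chain carbon bound to three saturated chain carbons (a number 18 percentage points higher from compound 1 to compound 4 (beyond the scatter)), so the lower number of compound 1 goes with that methyl and not with 3-carboxy-4-fluorophenyl. No measurement at hand gives a reason for either finding.

Every compound shown carries a carboxylic acid, so the effect of a methyl ester in its place remains open. Also open, on these data alone, is whether the chain on the carbonyl would matter in the same way with 4-carboxy-3-methylphenyl on the oxygen.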